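A Pyridine Isomer Near the Solubility Limit

A few compounds are considered here, and "the series" means these few. Any claim that something is new, unique, unknown or untested is made for them only; others in the source may bear on it.

Compound 1 `COc1ccncc1C(=O)NC(=O)Nc1ccc(-c2ccccc2)c(C(F)(F)F)c1` gives 6.6 ug/mL
Compound 2 `Cn1cc(C(=O)Nc2ccc(-c3cccnc3)c(C(F)(F)F)c2)c(=O)c2ccccc21` gives < 1 ug/mL

In a physicochemical assay for solubility, in phosphate buffer, at pH 7.4 (a lower number here means a less soluble compound, a higher number a more soluble compound), compound 2 gives < 1 ug/mL and that is a limit of the assay, not a number. Compound 3 `Cn1cc(C(=O)Nc2ccc(-c3ccccn3)c(C(F)(F)F)c2)c(=O)c2ccccc21` has the same atoms joined differently, with pyridin-2-yl in place of pyridin-3-yl on an aromatic carbon. For the measured compounds named here, no measured step bears on this change, so nothing beyond the scatter is expected in this assay in either direction. The expected change is small (a step that the limit leaves unreadable from compound 2 to compound 3). For compound 3 the estimate is 0.8 ug/mL with an expected range from 0.3 ug/mL to 2.5 ug/mL and a report at the limit remains likely.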

Compound 3, solubility: < 1 ug/mL
Compound 3 ended at the assay's limit; the forecaster's own chance of this, stated with the estimate: 70%; the middle value does not contradict the limit.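

In this assay, for the compounds shown here, compound 2 and compound 3 both end at a limit of the assay, and no step between them can be read. From the compounds shown here alone, whether the pyridin-3-yl of compound 2 and the pyridin-2-yl of compound 3 give different solubility stays open.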